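Two Fluorines in Place of a Methoxy Group

This account rests on a few compounds, and the source may have more. Where it says the series, first, only, none or still open, it means among the compounds named here.

Of the compounds shown here, two that share one core have so far been measured in a functional assay on SNB-19 cells (Homo sapiens) for cytotoxicity, read by sulforhodamine B assay, with a stated time of 48 h, tested at 0.1 uM; on this read-out higher numbers stand for a weaker effect at the one concentration tested and lower numbers for a stronger effect. Compound 1 `COc1cc(-c2cc(/C=C/C(=O)c3ccc(N)cc3)[nH]n2)cc(OC)c1OC` gives 94% in this assay. Compound 2 `COc1ccc(C(=O)/C=C/c2cc(-c3cc(OC)c(OC)c(OC)c3)n[nH]2)cc1` carries a methoxy in place of amino on an aromatic carbon and gives 88%. The step of a number 6 percentage points lower from compound 1 to compound 2 (within the scatter) lies within the scatter, so these two numbers cannot be separated. On the numbers shown, compound 2 stands as the lowest of the two, with compound 1 nearest and within the scatter of it.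

Compound 3 `COc1cc(-c2cc(/C=C/C(=O)c3ccc(F)c(F)c3)[nH]n2)cc(OC)c1OC` has not yet been measured. It differs from compound 2 in one place: 3,4-difluorophenyl in place of 4-methoxyphenyl on a carbonyl carbon. Going by the values given here, no measured step touches this part of the molecule; the only known step, from compound 1 to compound 2, altered a different group and moved the read-out within the scatter, so it offers no guide to the present change. Among the compounds with values here, with no bearing step, the expectation for compound 3 stays close to compound 2, with a wide range, and the expected step is a number 2 percentage points lower from compound 2 to compound 3 (within the scatter). The estimated value for compound 3 in this assay is 86%, from 65% to 100%.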

Compound 3, a percentage reported as activity, at one concentration (the size of the read-out at that concentration, not a potency): 87%
For compound 3 the middle estimate is 1 percentage points below the measured one; low and high end bracket the measured number.
By their numbers in this assay, from the lowest: compounds 3, 2 and 1 (each within the scatter of the next).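

At the group on the carbonyl carbon, 3,4-difluorophenyl in place of 4-methoxyphenyl gives a number 1 percentage points lower from compound 2 to compound 3 (within the scatter) in this assay, so this position has now been varied directly, with two fluorines entering and the methoxy oxygen leaving, and the two numbers cannot be separated. Against the 4-aminophenyl group of the first compound, the same 3,4-difluorophenyl group gives a number 7 percentage points lower from compound 1 to compound 3 (within the scatter), which means that the three aromatic groups tried on this carbonyl carbon all lie within the scatter of one another at the single concentration tested, and none of them can be ranked above another. No accompanying measurement offers an explanation for this result.

As far as these compounds go, it remains open whether a cyclohexyl group or a pyridine ring on the carbonyl carbon, or a carboxylic acid on the phenyl ring, would give a number beyond the scatter of these three. Also open, from the compounds shown here alone, is whether the three compounds would separate at other concentrations, as a single-concentration read-out is not a measure of potency.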